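Replacing the ether linker with a direct aryl group

This account rests on a few compounds, and the source may have more. Where it says the series, first, only, none or still open, it means among the compounds named here.

Measured so far:
- compound 1, `CCCCOc1nc(C(F)(F)F)ccc1CNC(=O)Nc1cccc2c(=O)[nH]ccc12`: 160 nM
- compound 2, `O=C(NCc1ccc(C(F)(F)F)nc1OCC1CCC1)Nc1cccc2c(=O)[nH]ccc12`: 63.2 nM
- compound 3, `O=C(NCc1ccc(C(F)(F)F)nc1OCc1ccccc1)Nc1cccc2c(=O)[nH]ccc12`: 78.6 nM

In an assay on CHO cells for agonist activity at transient receptor potential cation channel subfamily V member 1 (Homo sapiens) (on this read-out lower numbers stand for an effect already at smaller amounts and higher numbers for an effect only at larger amounts of compound), compound 3 gives 78.6 nM, the second highest of the three numbers. Its nearest neighbour is compound 2, with a 1.2-fold higher number from compound 2 to compound 3 (0.09 log units; within the scatter), so the two cannot be told apart. Compound 1 is furthest away: a 2.0-fold lower number from compound 1 to compound 3 (0.31 log units; beyond the scatter).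

Compound 4, `CC(C)c1cccc(-c2nc(C(F)(F)F)ccc2CNC(=O)Nc2cccc3c(=O)[nH]ccc23)c1`, differs from compound 3 in one place: 3-isopropylphenyl in place of benzyloxy on an aromatic carbon. All three measured steps changed the group on the saturated chain carbon bound to the ring oxygen while keeping that oxygen in place (a 2.5-fold lower number from compound 1 to compound 2 (0.40 log units; beyond the scatter), a 2.0-fold lower number from compound 1 to compound 3 (0.31 log units; beyond the scatter), a 1.2-fold higher number from compound 2 to compound 3 (0.09 log units; within the scatter)), and they were modest or within the scatter. None of them removes the oxygen or attaches an aromatic ring directly to the ring carbon, so none bears directly on this step. The expectation therefore rests on the observation that the three measured variants stay close together, with wide uncertainty about a change of this kind.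

For compound 4 the estimated step is a 1.5-fold higher number from compound 3 to compound 4 (0.18 log units; within the scatter), expected to be modest in either direction. Compound 4 is thus estimated at 120 nM, with a range from 30 nM to 500 nM.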

Compound 4, half-maximal effective concentration: 3.07 nM
Compound 4: middle estimate off by 39-fold (1.59 log units), on the high side, outside the stated range (below it).
By their numbers in this assay, from the lowest: compound 4; then compounds 2 and 3 (each within the scatter of the next); then compound 1.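

In this assay, this position proves far more sensitive than the ether compounds alone suggested. Putting 3-isopropylphenyl on the aromatic carbon in place of the whole oxygen-linked group gives a large step from each of them (a 26-fold lower number from compound 3 to compound 4 (1.41 log units; beyond the scatter); a 21-fold lower number from compound 2 to compound 4 (1.31 log units; beyond the scatter); a 52-fold lower number from compound 1 to compound 4 (1.72 log units; beyond the scatter)), whereas changes on the saturated chain carbon bound to the oxygen were modest or within the scatter. So compound 4 has the lowest number of the series, and keeping the oxygen while varying the chain gave no hint of this, although nothing measured here explains the size of the gain.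

Compound 4 loses the oxygen link and gains the isopropyl group in a single step, so the compounds shown leave open how much of the gain belongs to each change. An unsubstituted phenyl at the same carbon would address that split, while a cyclohexyl there would ask whether the new ring needs to be aromatic at all.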